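The source may report more compounds than this note shows. Statements on the series, on what has been measured and on what is new or still open speak of the compounds shown alone.

Of the compounds shown here, three sharing one core have been tested in a functional assay on NCI-H460 cells (Homo sapiens) for inhibition, read by MTT assay, with a stated time of 48 h; a higher number here means a weaker inhibitor, a lower number a stronger inhibitor. Compound 1 (`O=C(CC(c1ccccc1)C(C(=O)Nc1ccccn1)C(=O)Nc1ccccn1)c1ccccc1`) is reported as "not active" (no number reported). Among the measured compounds shown here, compound 2 (`O=C(CC(c1ccc(Cl)cc1)C(C(=O)Nc1ccccn1)C(=O)Nc1ccccn1)c1ccccc1`) gives 18900 nM, the only number among the three. Compound 3 (`O=C(CC(c1cccs1)C(C(=O)Nc1ccccn1)C(=O)Nc1ccccn1)c1ccccc1`) is reported as "not active" (no number reported), so it has no single number and, like compound 1, cannot be placed on the scale.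

Compound 4 (`O=C(CC(c1ccc([N+](=O)[O-])cc1)C(C(=O)Nc1ccccn1)C(=O)Nc1ccccn1)c1ccccc1`) has not yet been measured. Its structure has 4-nitrophenyl in place of thiophen-2-yl on a saturated chain carbon bound to two saturated chain carbons.

No measured step exists among these compounds, so the size of this step in this assay cannot be read from the data. The expectation is a modest move towards stronger inhibition, from no reported number to a weak one near that of compound 2 at 18900 nM. Compound 1 at "not active" (no number reported) shows that a number is not assured. For compound 4 the estimated value is 20000 nM, with an expected range from 8000 nM to 50000 nM.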

Compound 4, half-maximal inhibitory concentration: "not active" (no number reported)
No number was reported for compound 4; no gap can be computed for the estimate.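

With compound 3 and compound 4 both without a number in this assay, no step can be read between them, and no evidence bears on this result. The compounds shown leave open what separates compound 2, the only one with a number, from the others.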